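The source may report more compounds than this note shows. Statements on the series, on what has been measured and on what is new or still open speak of the compounds shown alone.

Measured so far:
compound 1 `Cc1nc(C)c(C(=O)Oc2ccc(/C=C/C(=O)O)cc2)nc1C` — 93.2%
compound 2 `CCOC(=O)/C=C/c1ccc(OC(=O)c2nc(C)c(C)nc2C)c(OC)c1` — 71.6%

In a functional assay on EA.hy 926 cells (Homo sapiens) for cytotoxicity, read by MTT assay, with stated times of 24 h and 12 h, tested at 100 uM (a lower number here means a weaker effect, a higher number a stronger effect of the compound at the concentration tested), compound 1 gives 93.2% and compound 2 gives 71.6%. Compound 2 stands lowest of the two numbers; its nearest neighbour is compound 1, which lies higher by a gap beyond the usual scatter. Among the compounds with values here, no step between the measured pair is broken down, so these two values are simply read side by side.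

Compound 3 `CCOC(=O)/C=C/c1ccc(OC(=O)c2nc(C)c(C)nc2C)cc1` is not yet measured. It differs from compound 2 by hydrogen in place of methoxy on an aromatic carbon. Compound 1, which also carries no methoxy, gives 93.2%, so an upward step is expected, of a size a number 10.4 percentage points higher from compound 2 to compound 3 (beyond the scatter). Compound 3 is estimated at 82%, with a range from 65% to 95%.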

Compound 3, a percentage reported as activity, at one concentration (the size of the read-out at that concentration, not a potency): 96.1%
Estimate against measurement, compound 3: 14.1 percentage points below, outside the stated range (above it).
By their numbers in this assay, from the lowest: compound 2; then compounds 1 and 3 (each within the scatter of the next).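

In this assay hydrogen in place of methoxy on the aromatic carbon meta to a 2-(ethoxycarbonyl)ethenyl group gives a number 24.5 percentage points higher from compound 2 to compound 3 (beyond the scatter) and is the only one of the two new steps that lies beyond the scatter. Ethyl in place of hydrogen on an oxygen next to a carbonyl group gives a number 2.9 percentage points higher from compound 1 to compound 3 (within the scatter) and leaves the ethyl ester and the free acid unseparated at this concentration. Nothing available explains the methoxy step.

On these data alone, whether a hydroxyl, a chlorine or an ethoxy group on this aromatic carbon reads like hydrogen or like methoxy stays open. So does the effect of an amide in place of the ethyl ester.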